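This account rests on a few compounds, and the source may have more. Where it says the series, first, only, none or still open, it means among the compounds named here.

Among the measured compounds shown here, in a functional assay on PANC-1 cells (Homo sapiens) for inhibition, read by MTT assay, with a stated time of 24 h (on this read-out lower numbers stand for stronger inhibition and higher numbers for weaker inhibition), compound 1 `CC1(C)[C@H]2CC[C@]1(C)N(Cc1cn(-c3cccc(F)c3)nn1)C(=O)C2` gives 220 nM, the lowest of the three numbers so far. Compound 2 `Cc1ccc(-n2cc(CN3C(=O)C[C@@H]4CC[C@@]3(C)C4(C)C)nn2)cc1` gives 270 nM and stands nearest, with a 1.2-fold higher number from compound 1 to compound 2 (0.09 log units; within the scatter). Compound 3 `COc1cccc(-n2cc(CN3C(=O)C[C@@H]4CC[C@@]3(C)C4(C)C)nn2)c1` gives 860 nM and stands furthest, with a 3.9-fold higher number from compound 1 to compound 3 (0.59 log units; beyond the scatter); between the other two, a 3.2-fold higher number from compound 2 to compound 3 (0.50 log units; beyond the scatter).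

Compound 4 `COc1ccc(-n2cc(CN3C(=O)C[C@@H]4CC[C@@]3(C)C4(C)C)nn2)cc1` has not yet been measured in this assay. It differs from compound 1 in one place: 4-methoxyphenyl in place of 3-fluorophenyl on an aromatic nitrogen. For the measured compounds named here, two measured steps bear on this. Methoxy in place of fluoro on the aromatic carbon brought a modest loss, a 3.9-fold higher number from compound 1 to compound 3 (0.59 log units; beyond the scatter), whereas 4-methylphenyl in place of 3-fluorophenyl stayed within the scatter, a 1.2-fold higher number from compound 1 to compound 2 (0.09 log units; within the scatter). The incoming 4-methoxyphenyl shares its methoxy with compound 3 and its 4-substitution with compound 2, so a modest rise is expected, probably smaller than that seen for compound 3 because the step to compound 2, a 1.2-fold higher number from compound 1 to compound 2 (0.09 log units; within the scatter), was flat. Compound 4 is therefore expected to give about 500 nM, estimated within 200 nM to 1200 nM, an expected step of a 2.3-fold higher number from compound 1 to compound 4 (0.36 log units; beyond the scatter).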

Compound 4, half-maximal inhibitory concentration: 330 nM
The estimate for compound 4 lay 1.5-fold (0.18 log units) above the measured number, within the range that was stated.
By their numbers in this assay, from the lowest: compounds 1, 2 and 4 (each within the scatter of the next); then compound 3.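

Within this set, the loss seen in compound 3 belongs to the 3-methoxyphenyl group and not to methoxy as such: in this assay, 4-methoxyphenyl in place of 3-methoxyphenyl gives a clear recovery (a 2.6-fold lower number from compound 3 to compound 4 (0.42 log units; beyond the scatter)). The 4-methoxyphenyl group also holds level with the 3-fluorophenyl group (a 1.5-fold higher number from compound 1 to compound 4 (0.18 log units; within the scatter)) and with the 4-methylphenyl group (a 1.2-fold higher number from compound 2 to compound 4 (0.09 log units; within the scatter)), so this position tolerates all three of these aryl groups without separating them. Nothing at hand explains why the two methoxyphenyl groups differ.

Open, on these data alone, is whether a 4-amino or 4-carboxylic acid phenyl group would stay level with these three aryl groups. Also open, as far as these compounds go, is whether 3-methylphenyl and 4-fluorophenyl groups would show a similar split between the 3- and 4-substituted forms, or whether that split is confined to methoxy.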